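The compounds below may be only part of what the source reports. "The series", "measured", "known", "first", "only" and "open" are said of these compounds alone.

Working notes on the series, read in a functional assay on IMR-32 cells (Homo sapiens) for antiproliferative activity, read by sulforhodamine B assay, with a stated time of 48 h; a higher number here means a weaker inhibitor of growth, a lower number a stronger inhibitor of growth. Compound 1 `CCCCCc1ccc(-c2cn(CCCN3C(=O)COc4ccccc43)nn2)cc1` gives 43500 nM, compound 2 `O=C1COc2ccccc2N1CCCn1cc(-c2ccccn2)nn1` gives 2000 nM, and compound 3 `O=C1COc2ccccc2N1CCCn1cc(CO)nn1` gives 5500 nM, the second highest of the three numbers. Compound 4 `O=C1COc2ccccc2N1CCCn1cc(C2(O)CCCCC2)nn1` carries 1-hydroxycyclohexyl in place of hydroxymethyl on an aromatic carbon. Among the compounds with values here, the one measured step at this place is modest a 2.8-fold higher number from compound 2 to compound 3 (0.44 log units; beyond the scatter). The high number of compound 1 43500 nM is the only hint of direction, and a weak one. No larger step is expected in this assay, and none beyond the scatter is the likeliest outcome, with any drift towards a higher number. The estimated step is a 1.5-fold higher number from compound 3 to compound 4 (0.16 log units; within the scatter). Compound 4 is estimated at 8000 nM, with an expected range of 2500 nM to 25000 nM.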

Compound 4, concentration for 50% growth inhibition: 1200 nM
Compound 4: middle estimate off by 6.7-fold (0.82 log units), on the high side; the whole stated range lies above it.
By their numbers in this assay, from the lowest: compounds 4 and 2 (each within the scatter of the next); then compound 3; then compound 1.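

In this assay 1-hydroxycyclohexyl in place of hydroxymethyl on this aromatic carbon moves the number down (a 4.6-fold lower number from compound 3 to compound 4 (0.66 log units; beyond the scatter)), so adding a six-membered non-aromatic ring of carbon only to the hydroxyl-bearing group does not cost activity here. An aromatic group is also not required at this position for a low number, as 1-hydroxycyclohexyl in place of pyridin-2-yl shows (a 1.7-fold lower number from compound 2 to compound 4 (0.22 log units; within the scatter)). Nothing available explains either step.

Still open, going by these compounds, is whether plain cyclohexyl, without the hydroxyl, or 1-aminocyclohexyl would hold the number of compound 4. Also open, on these data alone, is whether 1-hydroxycyclopentyl or 1-hydroxycycloheptyl would follow the same direction.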